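Hexyl to 1-methylheptyl on a carbonyl carbon

This account rests on a few compounds, and the source may have more. Where it says the series, first, only, none or still open, it means among the compounds named here.

In an ADME assay on Vero cells (Chlorocebus sabaeus) for cytotoxicity, read by reporter gene assay, with a stated time of 4 days (on this read-out lower numbers stand for stronger inhibition and higher numbers for weaker inhibition), compound 2 (`CCCCCCC(=O)OCC(C)(C)CC1=C(O)C(=O)c2ccccc2C1=O`) stands at 99300 nM as the higher of two numbers, against compound 1 (`CCCC(C)C(=O)OCC(C)(C)CC1=C(O)C(=O)c2ccccc2C1=O`) at 120 nM on the same read-out. Compound 3 (`CCCCCCC(C)C(=O)OCC(C)(C)CC1=C(O)C(=O)c2ccccc2C1=O`) carries 1-methylheptyl in place of hexyl on a carbonyl carbon. For the measured compounds named here, the only measured step bearing on this, an 830-fold higher number from compound 1 to compound 2 (2.92 log units; beyond the scatter) with hexyl in place of 1-methylbutyl, is large and runs the opposite way. With 1-methylheptyl differing from 1-methylbutyl, only part of that step is expected to return, as an estimated 25-fold lower number from compound 2 to compound 3 (1.39 log units; beyond the scatter) in this assay (a lower number). For compound 3 the estimate is 4000 nM (range 300 nM to 50000 nM).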

Compound 3, half-maximal inhibitory concentration: 450 nM
The estimate for compound 3 lay 8.9-fold (0.95 log units) above the measured number; measured number inside the range.
By their numbers in this assay, from the lowest: compound 1; then compound 3; then compound 2.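

In this assay the change from hexyl to 1-methylheptyl on a carbonyl carbon gives a 220-fold lower number from compound 2 to compound 3 (2.34 log units; beyond the scatter), so the high number of compound 2 does not simply follow from a longer chain. The step from 1-methylbutyl to 1-methylheptyl is much smaller, with a 3.8-fold higher number from compound 1 to compound 3 (0.57 log units; beyond the scatter), and both compounds with a 1-methyl group stand well below unbranched hexyl in compound 2. Nothing at hand explains this difference.

Open, going by these compounds, is whether a longer unbranched chain, such as octyl, would stay as high as hexyl. Also open, on these data alone, is how an amine or a carboxylic acid at the chain end would read.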